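Acylation of the Aniline Nitrogen in a Chalcone Series

A few compounds are considered here, and "the series" means these few. Any claim that something is new, unique, unknown or untested is made for them only; others in the source may bear on it.

Measured compounds:
compound 1, `COc1cc(/C=C/C(=O)c2cccc(NC(=O)c3cccs3)c2)ccc1O`, 90%
compound 2, `COc1cc(/C=C/C(=O)c2cccc(NC(=O)c3cc(Cl)cc(Cl)c3)c2)ccc1O`, 58%
compound 3, `COc1cc(/C=C/C(=O)c2cccc(N)c2)ccc1O`, 90%

In a functional assay on HUVEC cells (Homo sapiens) for inhibition, tested at 10 ug/mL (a higher number here means a stronger effect of the compound at the concentration tested, a lower number a weaker effect), compound 3 stands level with compound 1, and the two share the highest reading of the three; compound 2 sits lowest, as the step of a number 32 percentage points higher from compound 2 to compound 3 (beyond the scatter) shows. The step of no change at the digits printed from compound 1 to compound 3 (within the scatter) shows that taking off a (thiophen-2-yl)carbonyl group from the nitrogen on the aromatic ring made no difference beyond the scatter, whereas a number 32 percentage points lower from compound 1 to compound 2 (beyond the scatter) shows a large fall when a 3,5-dichlorophenyl replaces the thiophen-2-yl on the carbonyl carbon.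

Compound 4, `COC(=O)C(=O)Nc1cccc(C(=O)/C=C/c2ccc(O)c(OC)c2)c1`, has not yet been measured. It differs from compound 3 as follows: (methoxycarbonyl)carbonyl in place of hydrogen on a nitrogen on an aromatic ring. Both measured steps concern groups entering or leaving this same nitrogen, so they bear on the present change; one was flat and one was large. A small acyl group is again placed on the nitrogen, and the reading of compound 3 leaves little room for a rise, so for compound 4 a modest drop in this assay is expected, a number 12 percentage points lower from compound 3 to compound 4 (beyond the scatter), with compound 4 estimated at 78%, between 50% and 95%.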

Compound 4, a percentage reported as inhibition, at one concentration (the size of the read-out at that concentration, not a potency): 43%
Compound 4: middle estimate off by 35 percentage points, on the high side, and the stated range ends above it.
By their numbers in this assay, from the lowest: compound 4; then compound 2; then compounds 1 and 3 (each within the scatter of the next).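

In this assay, placing an acyl group on this nitrogen is shown for the first time to cost activity relative to the free amine, as a number 47 percentage points lower from compound 3 to compound 4 (beyond the scatter) makes plain. The carbonyl on the nitrogen cannot account for this alone, since compound 1 carries one too and stands level with compound 3, yet a number 47 percentage points lower from compound 1 to compound 4 (beyond the scatter) follows from exchanging thiophen-2-yl for methoxycarbonyl on that carbonyl carbon. Methoxycarbonyl, the only one of the three groups here with no ring, also falls short of 3,5-dichlorophenyl, with a number 15 percentage points lower from compound 2 to compound 4 (beyond the scatter) as the step, so what sits on the carbonyl carbon decides the reading.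

Nothing available explains why this group lowers the reading. On these data alone, it also remains open whether a carboxylic acid, an amine or a longer chain in place of methoxycarbonyl would recover the activity of compound 1.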